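Dropping the methoxy from compound 2: what to expect

A few compounds are considered here, and "the series" means these few. Any claim that something is new, unique, unknown or untested is made for them only; others in the source may bear on it.

Of the compounds shown here, three sharing one core have been measured in an assay on isolated protein for agonist activity at Bile acid receptor (Homo sapiens), read by AlphaScreen, with a stated time of 30 min; a lower number here means a smaller maximal response, a higher number a larger maximal response. Compound 1, `COc1ccc(C2SC(C)C(=O)Nc3c2c(C)nn3-c2ccccc2C)c(OC)c1`, gives 63% in this assay. Compound 2, `COc1cccc(-c2ccc([C@H]3S[C@@H](C)C(=O)Nc4c3c(C)nn4-c3ccccc3C)cc2)c1`, gives 41% in this assay and stands lowest of the three numbers. Its nearest neighbour is compound 1, whose number is higher by a margin beyond the scatter, and the furthest is compound 3, `COc1cc([C@H]2S[C@@H](C)C(=O)Nc3c2c(C)nn3-c2ccccc2C)ccc1Oc1ccccc1`, which gives 130% in this assay, again well beyond the scatter from compound 2. No pair among these three differs in only one place, so the gaps between them are read as gaps between values, not as steps tied to a single change.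

Compound 4, `Cc1ccccc1-n1nc(C)c2c1NC(=O)[C@H](C)S[C@@H]2c1ccc(-c2ccccc2)cc1`, has not yet been measured in this assay. It differs from compound 2 in one place: hydrogen in place of methoxy on an aromatic carbon. The methoxy sits on a six-membered aromatic ring of carbon only, meta to a large group, and its removal turns the 3-methoxyphenyl into phenyl.

For the measured compounds named here, with no single-change step among the measured compounds, the direction of this change rests on no measured precedent. The account therefore expects a modest step, a number 9 percentage points higher from compound 2 to compound 4 (within the scatter), that may not exceed the scatter. Compound 4 is estimated at 50%, within a range from 25% to 85%.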

Compound 4, largest response reached (reported as efficacy), in percent of the reference or control that the assay uses: 24%
Beside the measured number, compound 4's estimate is 26 percentage points above it, outside the stated range (below it).
By their numbers in this assay, from the lowest: compound 4; then compound 2; then compound 1; then compound 3.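

This is the first step among these compounds tied to a single change, and it gives that change a direction. In this assay hydrogen in place of methoxy gives a number 17 percentage points lower from compound 2 to compound 4 (beyond the scatter) and so shows that, on this pair, the 3-methoxyphenyl goes with a larger maximal response than the phenyl. The step is modest, but it shows that this aromatic carbon, meta to a large group, is not indifferent to what it carries, which the gaps among the earlier compounds could not show; nothing among the data offered here explains the direction of the step.

Still open, from the compounds shown here alone, is whether the response follows the oxygen or the whole methoxy group, and whether a hydroxyl, an ethoxy or an amine on the same carbon would give a number closer to that of the methoxy or further from it. A single pair also leaves open whether the same change would run the same way on other compounds sharing this core.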